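The source may hold more compounds than are shown below. What is called first, only, known or untested is meant among the compounds shown, and "the series" means these compounds.

Measured compounds:
Compound 1, `CSc1nc(NCCCNc2ccnc3cc(Cl)ccc23)c(C#N)c(-c2ccccc2)n1`, gives 100000 nM in an ADME assay on HeLa cells (Homo sapiens) for cytotoxicity, read by microscopy; a lower number here means that less compound is tolerated, a higher number that more compound is tolerated.
Compound 2, `CSc1nc(OCCCNc2ccnc3cc(Cl)ccc23)c(C#N)c(-c2ccccc2)n1`, gives 4000 nM in this assay.
Compound 3, `CSc1nc(NCCCCNc2ccnc3cc(Cl)ccc23)c(C#N)c(-c2ccc([N+](=O)[O-])cc2)n1`, gives 4000 nM in this assay.

Compound 3 stands level with compound 2 at the digits shown, and these two share the lowest number of the three, meaning they are tolerated by the cells at the lowest concentration. Compound 1 sits at a clearly higher number, a gap beyond the usual scatter, so it is tolerated at a higher concentration than compound 3.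

Compound 4, `CSc1nc(NCCCCNc2ccnc3cc(Cl)ccc23)c(C#N)c(-c2ccc(C)cc2)n1`, differs from compound 3 in a single place: methyl in place of nitro on an aromatic carbon. Among the measured compounds shown here, no pair of measured compounds isolates this change. Compound 1 carries an unsubstituted phenyl ring, but it also has a shorter chain than compound 3, so its higher number cannot be attributed to the ring substituent alone. With that caveat, removing the nitro moves compound 4 toward the ring pattern of compound 1, and a modest rise in the tolerated concentration is expected, though it may fall within the scatter. Compound 4 is therefore estimated at 10000 nM, with a plausible range of 2500 nM to 40000 nM in this assay. The expected step is a 2.5-fold higher number from compound 3 to compound 4 (0.40 log units; beyond the scatter).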

Compound 4, minimum cytotoxic concentration: 100000 nM
The estimate for compound 4 lay 10-fold (1.00 log units) below the measured number, outside the stated range (above it).
By their numbers in this assay, from the lowest: compounds 2 and 3 (each within the scatter of the next); then compounds 1 and 4 (each within the scatter of the next).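

With the rest of the structure unchanged, replacing nitro with methyl on the aromatic carbon para to a large group gives a 25-fold higher number from compound 3 to compound 4 (1.40 log units; beyond the scatter) in this assay. Among the compounds shown here, this is the first comparison here that isolates a single change, and it shows that the group at this one ring position can, on its own, shift the tolerated concentration by a large step; the earlier compounds differed in more than one place and could not separate the ring substituent from the other changes. No accompanying measurement bears on this pair, so the size of the step is known but what lies behind it is not.

As far as these compounds go, with only nitro and methyl compared at this position, it remains open whether other groups would track compound 3 or compound 4; an amine, a chlorine or a carboxylic acid in the same place, or a plain phenyl ring on this same chain, would help to show which of the two is the exception. From the compounds shown here alone, it is also open whether the same exchange gives a step of this size on a shorter chain, or on a longer one.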